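A Second Methyl and a Moved Group on the Phenyl Ring

A few compounds are considered here, and "the series" means these few. Any claim that something is new, unique, unknown or untested is made for them only; others in the source may bear on it.

Of the compounds shown here, three on a shared core have so far been measured in a functional assay on KB cells (Homo sapiens) for cytotoxicity (a higher number here means that more compound is needed for the effect, a lower number that less compound is needed), and they lie close together. Compound 1 (`COC1=C(C)C(=O)/C(=C(O)/C=C/c2cccc(OC)c2)C(=O)C1(C)C`) gives 2.4 ug/mL and compound 2 (`COC1=C(C)C(=O)/C(=C(O)/C=C/c2ccc(O)cc2)C(=O)C1(C)C`) gives 3 ug/mL in this read-out. Compound 3 (`COC1=C(C)C(=O)/C(=C(O)/C=C/c2ccc(C)cc2)C(=O)C1(C)C`) gives 1.9 ug/mL and stands within the scatter of both others. Compound 4 (`COC1=C(C)C(=O)/C(=C(O)/C=C/c2c(C)cccc2C)C(=O)C1(C)C`), not yet measured, carries 2,6-dimethylphenyl in place of the 4-methylphenyl of compound 3, on a double-bonded chain carbon bound to a double-bonded chain carbon (2,6-dimethylphenyl in place of 4-methylphenyl on a double-bonded chain carbon bound to a double-bonded chain carbon). The measured steps at this same place are all small. They are a 1.3-fold higher number from compound 1 to compound 2 (0.10 log units; within the scatter) and a 1.3-fold lower number from compound 1 to compound 3 (0.10 log units; within the scatter) and, for methyl in place of hydroxy on an aromatic carbon, a 1.6-fold lower number from compound 2 to compound 3 (0.20 log units; within the scatter) and none leaves the scatter. Within the data shown here, no measured compound carries 2,6-dimethylphenyl, so these steps are only an indirect guide and the range should stay wide. On that basis no step beyond the scatter is expected in this assay for this change. The expected step is a 1.2-fold higher number from compound 3 to compound 4 (0.08 log units; within the scatter) and it rests on those three small steps. For compound 4 the estimated value is 2.3 ug/mL with a range of 0.9 ug/mL to 5.5 ug/mL expected.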

Compound 4, concentration for half-maximal effect: 2.1 ug/mL
Estimate against measurement, compound 4: 1.1-fold (0.04 log units) above; low and high end bracket the measured number.
By their numbers in this assay, from the lowest: compounds 3, 4, 1 and 2 (each within the scatter of the next).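

In this assay, 2,6-dimethylphenyl behaves like the aryl groups before it, with a 1.1-fold higher number from compound 3 to compound 4 (0.04 log units; within the scatter), a 1.4-fold lower number from compound 2 to compound 4 (0.15 log units; within the scatter) and a 1.1-fold lower number from compound 1 to compound 4 (0.06 log units; within the scatter). The earlier compounds covered only 3-methoxyphenyl, 4-hydroxyphenyl and 4-methylphenyl on the double-bonded chain carbon, whereas compound 4 shows that exchanging 4-methylphenyl for 2,6-dimethylphenyl also leaves the number within the scatter, so none of the four aryl groups shown can be told apart at this place in this read-out. Nothing available explains why these changes leave the number so little altered.

The compounds shown leave open whether this flat picture would survive a more different group on the phenyl ring, such as an amine or a carboxylic acid, or a longer chain at this place. All four also share the same core, so they give no information on how the number responds to changes elsewhere in the molecule, and they cannot say whether any substituent at this place can move it beyond the scatter.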